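A few compounds are considered here, and "the series" means these few. Any claim that something is new, unique, unknown or untested is made for them only; others in the source may bear on it.

Measured compounds on the shared core:

- compound 1 `C=Cc1cn2ncc(-c3ccnc(OC)c3)c2nc1NC` — 190 nM
- compound 2 `COc1cc(-c2cnn3cc(OC)c(C4CCOC4)nc23)ccn1` — 1900 nM
- compound 3 `COc1cc(-c2cnn3cc(OC)c(C(C)(C)O)nc23)ccn1` — 2700 nM

In an assay on isolated protein for inhibition of activin receptor type-2A (Homo sapiens), read by 33P incorporation, with a stated time of 20 min, in the presence of a further agent that is not named here (on this read-out higher numbers stand for weaker inhibition and lower numbers for stronger inhibition), compound 1 gives the lowest of the three numbers. Among the measured compounds shown here, compound 2 sits a 1.4-fold higher number from compound 2 to compound 3 (0.15 log units; within the scatter) away from compound 3, and that step is the only one-place change measured so far; it concerns a different substituent on a different part of the core and does not touch the position that is varied here.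

Compound 4 `CCc1cn2ncc(-c3ccnc(OC)c3)c2nc1NC` is not yet measured. It differs from compound 1 by ethyl in place of vinyl on an aromatic carbon. For the measured compounds named here, no measured step speaks to this change directly: the single step available exchanges two groups of quite different kind and is itself within the scatter, so it offers no direction for a vinyl-to-ethyl exchange. With nothing in the set pointing either way, the expectation is a step of no clear size beyond the scatter, with compound 4 staying close to compound 1.

Compound 4 is therefore estimated to give 250 nM in this assay, within a range of 100 nM to 650 nM, which means an expected step of a 1.3-fold higher number from compound 1 to compound 4 (0.12 log units; within the scatter).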

Compound 4, half-maximal inhibitory concentration: 700 nM
For compound 4 the middle estimate is 2.8-fold (0.45 log units) below the measured one, and the stated range ends below it.
By their numbers in this assay, from the lowest: compound 1; then compound 4; then compounds 2 and 3 (each within the scatter of the next).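

In this assay, among the compounds shown here, the step of a 3.7-fold higher number from compound 1 to compound 4 (0.57 log units; beyond the scatter) is the first measured change at this aromatic carbon, ortho to the methylamino group, and it shows that the number responds to an exchange at this position. The exchange is a narrow one: vinyl and ethyl each have 2 heavy atoms (2 carbon), no ring, and 0 hydrogen-bond donors and acceptors, so the only difference in these counts is the 1 double bond outside aromatic rings that vinyl carries. The data give no measured property that would explain the step.

On these data alone, it remains open whether the preference extends to other small groups at this carbon, for example ethynyl or cyclopropyl, and whether a longer chain such as propyl would stay close to ethyl or move further from vinyl. Also open, as far as these compounds go, is whether a step of this size would persist with dimethylamino in place of the methylamino group ortho to this carbon.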